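The source may hold more compounds than are shown below. What is called first, only, known or untested is meant among the compounds shown, and "the series" means these compounds.

Compound 1, `COc1ccc(C(=O)/C=C/c2cn(-c3ccccc3)nc2-c2cccnc2)c(OC)c1`: 2400 nM
Compound 2, `COc1ccc(C(=O)/C=C/c2cn(-c3ccccc3)nc2-c2ccncc2)c(OC)c1OC`: 3700 nM
Compound 3, `COc1ccc(OC)c(C(=O)/C=C/c2cn(-c3ccccc3)nc2-c2ccncc2)c1`: 1700 nM

All three compounds share a core and were tested in a functional assay on Huh-7 cells (Homo sapiens) for inhibition, read by sulforhodamine B assay, with a stated time of 72 h; a higher number here means a weaker inhibitor, a lower number a stronger inhibitor. Compound 3 gives the lowest of the three numbers, yet its gap to compound 1 lies within the scatter, so the two cannot be ordered; only compound 2 sits clearly apart, with a number beyond the scatter from compound 3.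

Compound 4, `COc1ccc(C(=O)/C=C/c2cn(-c3ccccc3)nc2-c2ccncc2)c(OC)c1`, has not been measured in this assay. Compared with compound 3 the change is 2,4-dimethoxyphenyl in place of 2,5-dimethoxyphenyl on a carbonyl carbon. Compound 1 already carries a 2,4-dimethoxyphenyl on its carbonyl carbon, with a different pyridyl on the shared core, and compound 1 gives 2400 nM in this assay. Going by the values given here, no directly comparable pair is available, so the step is judged from the spread of the three numbers. For compound 4 the expected step is a 1.3-fold higher number from compound 3 to compound 4 (0.11 log units; within the scatter), a mild rise at most, not beyond the scatter. Compound 4 is thus expected to give 2200 nM in this assay, within a range from 1000 nM to 5000 nM.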

Compound 4, half-maximal inhibitory concentration: 4400 nM
Beside the measured number, compound 4's estimate is 2.0-fold (0.30 log units) below it, within the range that was stated.
By their numbers in this assay, from the lowest: compounds 3, 1, 2 and 4 (each within the scatter of the next, the first and the last beyond it).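

In this assay the two methoxy groups alone were moved, with 2,4-dimethoxyphenyl in place of 2,5-dimethoxyphenyl on a carbonyl carbon, and this gave a 2.6-fold higher number from compound 3 to compound 4 (0.41 log units; beyond the scatter) on the same atoms, so at this position the arrangement of the methoxy groups counts for something, if modestly. The other two changes do not separate their compounds: hydrogen in place of methoxy on an aromatic carbon gives a 1.2-fold higher number from compound 2 to compound 4 (0.08 log units; within the scatter) and pyridin-4-yl in place of pyridin-3-yl on an aromatic carbon gives a 1.8-fold higher number from compound 1 to compound 4 (0.26 log units; within the scatter) in this series. Nothing available explains the effect of moving the methoxy groups.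

The compounds shown leave open whether the same step appears with pyridin-3-yl on the shared core. They also leave open how a hydroxy or dimethylamino group would read in place of a methoxy at this position.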